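Aryl variation at the pyrazole carbon next to the carboxy group

A few compounds are considered here, and "the series" means these few. Any claim that something is new, unique, unknown or untested is made for them only; others in the source may bear on it.

Measured compounds:
compound 1 `COc1cccc(-c2c(C)nn(-c3nc(-c4ccc(Cl)c(Cl)c4)c(SC(C)C)s3)c2C(=O)O)c1` — 14000 nM
compound 2 `CC(=O)Nc1ccc(-c2c(C)nn(-c3nc(-c4ccc(Cl)c(Cl)c4)c(SC(C)C)s3)c2C(=O)O)cc1` — 139000 nM
compound 3 `Cc1cc(-c2c(C)nn(-c3nc(-c4ccc(Cl)c(Cl)c4)c(SC(C)C)s3)c2C(=O)O)cc(C)n1` — 580 nM

All three share one core and differ only in the aromatic group on the five-membered ring. In a functional assay on BJAB cells (Homo sapiens) for antiproliferative activity, with a stated time of 4 days (a lower number here means that less compound is needed, a higher number that more compound is needed for the effect), compound 3 gives the lowest number of the three, with a 24-fold lower number from compound 1 to compound 3 (1.38 log units; beyond the scatter) and a 240-fold lower number from compound 2 to compound 3 (2.38 log units; beyond the scatter) both beyond the scatter. Compound 1 and compound 2, each carrying a six-membered aromatic ring of carbon only, stand well apart from it; between these two, a 9.9-fold higher number from compound 1 to compound 2 (1.00 log units; beyond the scatter).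

The next compound, compound 4 `Cc1ccc(-c2c(C)nn(-c3nc(-c4ccc(Cl)c(Cl)c4)c(SC(C)C)s3)c2C(=O)O)cc1`, has not been measured in this assay. Its change from compound 3 is 4-methylphenyl in place of 2,6-dimethylpyridin-4-yl on an aromatic carbon. Among the compounds with values here, no measured step covers exactly this exchange. The closest evidence is the pair of steps from compound 1 and compound 2 to compound 3, in which the ring with one hetero atom gave a much lower number than either all-carbon ring. Going the other way, a higher number is therefore expected, probably of the order of a 24-fold lower number from compound 1 to compound 3 (1.38 log units; beyond the scatter) rather than none beyond the scatter, though the 4-methylphenyl group has no measured counterpart here.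

Compound 4 is estimated at 8000 nM (range 1500 nM to 40000 nM), an expected step of a 14-fold higher number from compound 3 to compound 4 (1.14 log units; beyond the scatter).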

Compound 4, half-maximal effective concentration: 3800 nM
Compound 4: middle estimate off by 2.1-fold (0.32 log units), on the high side; the range from low to high includes it.
By their numbers in this assay, from the lowest: compound 3; then compound 4; then compound 1; then compound 2.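

In this assay the ring with one hetero atom keeps its lead over an all-carbon ring carrying a methyl group, with a 6.6-fold higher number from compound 3 to compound 4 (0.82 log units; beyond the scatter) and the lowest of the four numbers staying with compound 3. The all-carbon rings themselves now spread widely at this position: there is a 37-fold lower number from compound 2 to compound 4 (1.56 log units; beyond the scatter) for methyl in place of acetamido on the phenyl ring and a 3.7-fold lower number from compound 1 to compound 4 (0.57 log units; beyond the scatter) for 4-methylphenyl in place of 3-methoxyphenyl. The large earlier gaps between compound 3 and the all-carbon rings therefore cannot be read as a matter of the ring nitrogen alone, since the choice of group on the phenyl ring moves the number by as much or more.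

Still open, as far as these compounds go, is how the step to compound 4 divides between the ring nitrogen and the methyl groups, a question that a plain pyridin-4-yl and a dimethylphenyl group would address, along with whether an amine or a carboxylic acid on the ring fits the same trend. Nothing available here explains the size of any of these steps.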